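Cyanocycloalkyl swaps and permeability in the sulfonamide series

A few compounds are considered here, and "the series" means these few. Any claim that something is new, unique, unknown or untested is made for them only; others in the source may bear on it.

- compound 1 `N#C[C@H]1C[C@@H]1CN([C@H](CCC(F)(F)F)C(N)=O)S(=O)(=O)c1ccc(Cl)cc1`: 21.5 10^-6 cm/s
- compound 2 `N#C[C@H]1C[C@@H](CN([C@H](CCC(F)(F)F)C(N)=O)S(=O)(=O)c2ccc(Cl)cc2)C1`: 24.1 10^-6 cm/s
- compound 3 `N#C[C@H]1C[C@H](CN([C@H](CCC(F)(F)F)C(N)=O)S(=O)(=O)c2ccc(Cl)cc2)C1`: 24.9 10^-6 cm/s

In an ADME assay on MDCKII-LE cells (Canis lupus familiaris) for permeability (a lower number here means that the compound crosses the layer more slowly, a higher number that the compound crosses the layer faster), compound 3 gives 24.9 10^-6 cm/s, within the scatter of compound 1 and compound 2. Compound 4 `N#CC1(CN([C@H](CCC(F)(F)F)C(N)=O)S(=O)(=O)c2ccc(Cl)cc2)CC1` carries 1-cyanocyclopropyl in place of 3-cyanocyclobutyl on a saturated chain carbon bound to a sulfonamide nitrogen.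

The nearest measured ring changes are small: a 1.1-fold higher number from compound 1 to compound 2 (0.05 log units; within the scatter), and a 1.2-fold higher number from compound 1 to compound 3 (0.06 log units; within the scatter). Also small is a 1.0-fold higher number from compound 2 to compound 3 (0.01 log units; within the scatter), given (the fact that compounds 2 and 3 differ only in the configuration as drawn). These steps run from the cyclopropyl to the cyclobutyl, and the nitrile sits differently in compound 4, so they are only a guide.

No step beyond the scatter is expected in this assay, and the estimate is a 1.1-fold lower number from compound 3 to compound 4 (0.05 log units; within the scatter). Compound 4 is expected at 22 10^-6 cm/s, with an estimated range of 13 10^-6 cm/s to 35 10^-6 cm/s.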

Compound 4, apparent permeability: 29.9 10^-6 cm/s
Estimate against measurement, compound 4: 1.4-fold (0.13 log units) below; low and high end bracket the measured number.
By their numbers in this assay, from the lowest: compounds 1, 2, 3 and 4 (each within the scatter of the next).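

In this assay, 1-cyanocyclopropyl in place of 3-cyanocyclobutyl on a saturated chain carbon bound to a sulfonamide nitrogen stays within the scatter for both ring isomers (a 1.2-fold higher number from compound 3 to compound 4 (0.08 log units; within the scatter) and a 1.2-fold higher number from compound 2 to compound 4 (0.09 log units; within the scatter)). The same holds against 2-cyanocyclopropyl (a 1.4-fold higher number from compound 1 to compound 4 (0.14 log units; within the scatter)), so the read-out at this position also tolerates a group without the defined stereocentres of 3-cyanocyclobutyl. The information available offers no explanation specific to compound 4.

On these data alone, whether an amine or a carboxylic acid in place of the nitrile, or a longer chain at this place, would give a step beyond the scatter stays open.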